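The source may report more compounds than this note shows. Statements on the series, on what has been measured and on what is new or still open speak of the compounds shown alone.

Measured in a functional assay on DU-145 cells (Homo sapiens) for inhibition, read by trypan blue exclusion, with a stated time of 96 h; a higher number here means a weaker inhibitor of growth, a lower number a stronger inhibitor of growth:
- compound 1 `Cc1ccc(S/C(=C/c2sccc2C)C(=O)c2ccc(Br)cc2)cc1`: 50000 nM
- compound 2 `COc1ccc(/C=C(/Sc2ccc(C)cc2)C(=O)c2ccc(Br)cc2)cc1`: 50000 nM
- compound 3 `COc1ccc(/C=C(/SCc2ccc(F)cc2)C(=O)c2ccc(Br)cc2)cc1`: 50000 nM

Compound 1 and compound 3 stand level with compound 2 at 50000 nM, so this small set shows no spread in this assay. Compound 4 `Cc1ccc(S/C(=C/c2ccc(-c3ccccc3)cc2)C(=O)c2ccc(Br)cc2)cc1` has not yet been measured. It differs from compound 2 in one place, with phenyl in place of methoxy on an aromatic carbon, para to a large group (phenyl in place of methoxy on an aromatic carbon).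

Within the data shown here, two measured steps bear on this change, though neither makes this exact swap. The closer one exchanges the whole 4-methoxyphenyl group that holds the methoxy: no change at the digits printed from compound 1 to compound 2 (within the scatter). The other alters the group on sulfur: no change at the digits printed from compound 2 to compound 3 (within the scatter). Neither step goes beyond the scatter, so no step beyond the scatter is expected in this assay, in either direction. Three equal values are a thin guide to a new group, however, so the range is kept wide. The estimated step is a 1.3-fold lower number from compound 2 to compound 4 (0.10 log units; within the scatter). For compound 4 the expected value is 40000 nM, with an estimated range from 15000 nM to 60000 nM.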

Compound 4, concentration for 50% growth inhibition: 50000 nM
Compound 4: middle estimate off by 1.3-fold (0.10 log units), on the low side; measured number inside the range.
By their numbers in this assay, from the lowest: compounds 1, 2, 3 and 4 (each within the scatter of the next).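

In this assay the exchange of methoxy for phenyl gives no change at the digits printed from compound 2 to compound 4 (within the scatter) even though a six-membered aromatic ring of six heavy atoms enters where two heavy atoms leave. The earlier steps shown here replaced the whole 4-methoxyphenyl group or changed the group on sulfur, whereas this one alters only the group on an aromatic carbon, para to a large group, and shows that losing the hydrogen-bond acceptor of the methoxy leaves the number unmoved. All four compounds now share one printed value, so this change separates none of them. No measured evidence accounts for this flat result.

From the compounds shown here alone, whether any group at this position can lower the number remains open, and an amine or a carboxylic acid in place of the phenyl would test that. Also open, going by these compounds, is whether replacing the bromo group on the shared core would change the reading.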